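Swapping a methylsulfanyl for a cyclopropyl on the shared core

This account rests on a few compounds, and the source may have more. Where it says the series, first, only, none or still open, it means among the compounds named here.

Of the compounds shown here, three have been measured in an assay on Sf21 cells for inhibition of mitogen-activated protein kinase kinase kinase 13 (Homo sapiens), read by HTRF, with a stated time of 1.5 h; on this read-out higher numbers stand for weaker inhibition and lower numbers for stronger inhibition. Compound 1 `CCOC(=O)N1C[C@@H]2C[C@H]1CN2c1nc(-c2cnc(N)c(OC(F)F)n2)cc(N2CC3CC2C3)n1` gives 13 nM. Compound 2 `CSc1cc(-c2cnc(N)c(OC(F)F)n2)nc(N2C[C@@H]3C[C@H]2CO3)n1` gives 45 nM. Compound 3 `Nc1ncc(-c2cc(C3CC3)nc(N3C[C@@H]4C[C@H]3CO4)c2)nc1OC(F)F` gives 29 nM. On these numbers compound 2 sits at the high end of the three: its gap to compound 3 lies within the usual scatter of repeated measurements, so the two cannot be told apart, whereas its gap to compound 1 lies beyond that scatter, so compound 1 is the clearer inhibitor of the pair.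

The next compound, compound 4 `Nc1ncc(-c2cc(C3CC3)nc(N3C[C@@H]4C[C@H]3CO4)n2)nc1OC(F)F`, is built from compound 2 by one change: cyclopropyl in place of methylsulfanyl on an aromatic carbon. For the measured compounds named here, no pair of measured compounds differs by exactly this change, so there is no measured step to lean on. Compound 3 carries the same cyclopropyl, but on a different core, so its value of 29 nM gives only a loose hint that a cyclopropyl at this position is tolerated.

The step expected in this assay from compound 2 to compound 4 is therefore small, a 1.3-fold lower number from compound 2 to compound 4 (0.11 log units; within the scatter), and not beyond the scatter in either direction. Compound 4 is expected to give about 35 nM, within a range of 12 nM to 100 nM.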

Compound 4, half-maximal inhibitory concentration: 61 nM
For compound 4 the middle estimate is 1.7-fold (0.24 log units) below the measured one, and the stated range covers the measured number.
By their numbers in this assay, from the lowest: compound 1; then compounds 3, 2 and 4 (each within the scatter of the next, the first and the last beyond it).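

In this assay, for the compounds shown here, cyclopropyl in place of methylsulfanyl on an aromatic carbon gives a 1.4-fold higher number from compound 2 to compound 4 (0.13 log units; within the scatter), and this is the first measured step for this change. At this place, next to the ring nitrogen and opposite the other ring nitrogen, the two groups therefore cannot be told apart, even though the swap removes the sulfur and adds a three-membered ring of carbon. No measurement of any property of these two groups accompanies this result, so it offers no explanation.

The compounds shown leave open whether other groups at this position, such as an amine, a methoxy group or a longer chain like propyl, would also stay within the scatter of these two or would move the number clearly in either direction. Going by these compounds alone, whether the same swap reads the same way with a different group at the other substituted position of the ring also stays open, since this single pair is the only measured example of the change.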